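The compounds below may be only part of what the source reports. "The series", "measured", "known", "first", "only" and "open" are said of these compounds alone.

Compound 2 `COc1ccc(C(=O)/C=C/c2cc(-c3cc(OC)c(OC)c(OC)c3)n[nH]2)cc1` gives 93% in a functional assay on NCI-H322M cells (Homo sapiens) for cytotoxicity, read by sulforhodamine B assay, with a stated time of 48 h, tested at 1 uM; on this read-out higher numbers stand for a weaker effect at the one concentration tested and lower numbers for a stronger effect. Compound 1 `COc1cc(-c2cc(/C=C/C(=O)c3ccc(Cl)c(Cl)c3)[nH]n2)cc(OC)c1OC` gives 94% in this assay, and the step of a number 1 percentage points lower from compound 1 to compound 2 (within the scatter) lies within the scatter, so the two stand together rather than apart. Compound 3 `COc1cc(-c2cc(/C=C/C(=O)c3ccc(F)c(F)c3)[nH]n2)cc(OC)c1OC` differs from compound 2 by 3,4-difluorophenyl in place of 4-methoxyphenyl on a carbonyl carbon. Among the measured compounds shown here, the only measured step bearing on this change, another swap of the group on a carbonyl carbon, is a number 1 percentage points lower from compound 1 to compound 2 (within the scatter), which was small. No step beyond the scatter is therefore expected for compound 3 in this assay, and its value is estimated at 92%, within 78% to 102%. That estimate corresponds to an expected step of a number 1 percentage points lower from compound 2 to compound 3 (within the scatter).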

Compound 3, a percentage reported as activity, at one concentration (the size of the read-out at that concentration, not a potency): 86%
Compound 3: the middle estimate sits 6 percentage points above what was measured; the range from low to high includes it.
By their numbers in this assay, from the lowest: compounds 3, 2 and 1 (each within the scatter of the next).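

Swapping the group on the carbonyl carbon for 3,4-difluorophenyl gives a number 7 percentage points lower from compound 2 to compound 3 (within the scatter) when it replaces 4-methoxyphenyl and a number 8 percentage points lower from compound 1 to compound 3 (within the scatter) when it replaces 3,4-dichlorophenyl. All three groups tried at this place therefore stand together in this assay, and the new group opens no real gap. Nothing available bears on the small differences that remain.

Still open, going by these compounds, is whether a phenyl ring carrying an amine or a carboxylic acid at this place would move the number beyond the scatter. A longer chain in place of the ring leaves the same question.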